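The source may hold more compounds than are shown below. What is called first, only, known or untested is meant among the compounds shown, and "the series" means these compounds.

Compound 1 `Cc1nn2c(-c3nc4cc(Cl)ccc4[nH]3)c(-c3ccccc3)nc2s1` is tested in a functional assay on ME-180 cells (Homo sapiens) for antiproliferative activity, read by MTT assay (on this read-out higher numbers stand for weaker inhibition and lower numbers for stronger inhibition), where compound 1 gives 5400 nM. Compound 3 `Cc1ccc(-c2nc3sc(C)nn3c2-c2nc3cc(Cl)ccc3[nH]2)cc1` differs from it by one change, (methyl in place of hydrogen on an aromatic carbon), and in this assay compound 3 gives 3600 nM, a step of a 1.5-fold lower number from compound 1 to compound 3 (0.18 log units; within the scatter). Compound 2 `Cc1ccc2[nH]c(-c3c(-c4ccc(F)cc4)nc4sc(C)nn34)nc2c1` rests on a different core; how the two cores differ is not broken down here. In this assay compound 2 gives 6600 nM. Compound 4 `Cc1nn2c(-c3nc4cc(C)c(C)cc4[nH]3)c(-c3ccc(F)cc3)nc2s1` is built from compound 2 by methyl in place of hydrogen on an aromatic carbon. Among the compounds with values here, this is the same kind of change as the one from compound 1 to compound 3, not the same: there the new methyl sits on a six-membered aromatic ring of carbon only, para to a large group, while here it sits on a six-membered aromatic ring of carbon only that is part of a fused or bridged system of two rings, ortho to a methyl group, meta to a fused ring and para to a fused ring. The expected step is a 1.5-fold lower number from compound 2 to compound 4 (0.17 log units; within the scatter), resting on the earlier step of a 1.5-fold lower number from compound 1 to compound 3 (0.18 log units; within the scatter), which stayed within the scatter. Compound 4 is therefore expected to give 4500 nM, between 2000 nM and 10000 nM.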

Compound 4, half-maximal inhibitory concentration: 6100 nM
Compound 4: the middle estimate sits 1.4-fold (0.13 log units) below what was measured, within the range that was stated.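

In this assay, placing the new methyl on compound 2 gives a 1.1-fold lower number from compound 2 to compound 4 (0.03 log units; within the scatter), so this step is too small to tell apart from repeat-to-repeat variation. Set beside the earlier step, it does not stand out as different: the same change on two cores in this assay, a 1.5-fold lower number (0.18 log units; within the scatter) from compound 1 to compound 3 and a 1.1-fold lower number (0.03 log units; within the scatter) from compound 2 to compound 4, 1.4-fold (0.14 log units) apart, within the scatter of two such steps. This shows only that methyl in place of hydrogen on an aromatic carbon stayed within the scatter on both cores, even though it sits on a different kind of ring in each; it does not show that the change has a real effect that carries from one core to the other, and two pairs are a thin basis for any rule.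

The compounds shown leave open whether a different group on these aromatic carbons, such as an amine, a carboxylic acid or a longer chain, would move the number beyond the scatter. They also leave open whether the methyl step would look the same on other cell types.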